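A few compounds are considered here, and "the series" means these few. Any claim that something is new, unique, unknown or untested is made for them only; others in the source may bear on it.

Measured compounds:
compound 1 `CCCCCSc1nnc(COc2cc(C)c3c(C)cc(=O)oc3c2)o1` — in a functional assay on MCF7 cells (Homo sapiens) for antiproliferative activity, read by MTT assay, with a stated time of 24 h (a lower number here means a stronger inhibitor, a higher number a weaker inhibitor), compound 1 gives > 100000 nM, a limit of the assay and not a number.
compound 2 `CCCCCCSc1nnc(COc2cc(C)c3c(C)cc(=O)oc3c2)o1` — in this assay compound 2 gives > 100000 nM, likewise a limit of the assay.

Going by the values given here, compound 2 stands only at a limit in this assay; no number is available for it, and the one other value shown is also a limit. Among the compounds with values here, the single measured step is a step that the two limits leave unreadable from compound 1 to compound 2; both of its ends sit at the limit of > 100000 nM in this assay, at which 2 of the 2 values shown sit, so its size cannot be read.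

Compound 3 `Cc1cc(OCc2nnc(SCc3cccc(F)c3)o2)cc2oc(=O)cc(C)c12` is not yet measured in this assay. It differs from compound 2 by 3-fluorophenyl in place of pentyl on a saturated chain carbon bound to a sulfur. The measured step from compound 1 to compound 2 bears on this only weakly: it concerns methyl in place of hydrogen on the chain, not pentyl against 3-fluorophenyl, and it is unreadable. With both measured values at the limit, no step size or direction in this assay can be derived from the data; the most likely outcome for compound 3 is a further limit. Compound 3 is therefore estimated at 150000 nM (range 30000 nM to 1000000 nM). That estimate is expected to correspond to a step that the limit leaves unreadable from compound 2 to compound 3.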

Compound 3, half-maximal inhibitory concentration: 26000 nM
Estimate against measurement, compound 3: 5.8-fold (0.76 log units) above; measured number below the stated range.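

Among the three compounds, compound 3 alone gives a number rather than a limit in this assay, so the group on the saturated chain carbon bound to a sulfur can move the read-out in this series. Placing 3-fluorophenyl there in place of pentyl gives an at least 3.8-fold lower number from compound 2 to compound 3 (0.58 log units; beyond the scatter), and placing it there in place of butyl gives an at least 3.8-fold lower number from compound 1 to compound 3 (0.58 log units; beyond the scatter). Both steps lie beyond the scatter, whereas the step between the two alkyl chains could not be read, but their full sizes stay unknown and only their lower bounds can be stated: the limit of > 100000 nM in this assay, at which 2 of the 3 values shown sit.

The change brings in an aromatic ring and a fluorine together, so the compounds shown do not separate the contribution of the ring from that of the fluorine, and an unsubstituted benzyl on the sulfur would be needed to tell them apart. As far as these compounds go, it also remains open whether other groups at this place, such as a chlorobenzyl or a chain ending in an amine or a carboxylic acid, would lower the number further in this assay.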